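Methoxy added to the second aryl ring of a bromoacrylamide

The source may report more compounds than this note shows. Statements on the series, on what has been measured and on what is new or still open speak of the compounds shown alone.

Compound 1 `Nc1cccc(-c2cn3nc(Cc4ccccc4)sc3n2)c1` gives 4700 nM in a functional assay on FM3A cells (Mus musculus) for inhibition, read by cell counting, with a stated time of 2 days; a lower number here means a stronger inhibitor, a higher number a weaker inhibitor. Compound 2 `COc1ccc(Cc2nn3cc(-c4cccc(N)c4)nc3s2)cc1` carries the change methoxy in place of hydrogen on an aromatic carbon and in this assay compound 2 gives 100000 nM, a step of a 21-fold higher number from compound 1 to compound 2 (1.33 log units; beyond the scatter). Compound 3 `C=C(Br)C(=O)Nc1cccc(-c2cn3nc(-c4cccc(OC)c4)sc3n2)c1` has the lowest of the three numbers, giving 500 nM in this assay; the difference between the core of compound 3 and the core of compound 1 is not broken down here. Compound 4 `C=C(Br)C(=O)Nc1cccc(-c2cn3nc(-c4ccc(OC)c(OC)c4)sc3n2)c1` is not yet measured and differs from compound 3 by methoxy in place of hydrogen on an aromatic carbon. This is the same kind of change as that from compound 1 to compound 2, but not the same: in compound 4 the entering group sits ortho to a methoxy group, which the place in compound 2 does not, while both sit para to a large group. Among the compounds with values here, only one measured example of this change exists, and it stands on a different core. The expectation for compound 4 is a weakening step of a 6.0-fold higher number from compound 3 to compound 4 (0.78 log units; beyond the scatter), smaller than the measured one because the surroundings differ from those of a 21-fold higher number from compound 1 to compound 2 (1.33 log units; beyond the scatter). Compound 4 is estimated at 3000 nM, between 800 nM and 15000 nM.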

Compound 4, half-maximal inhibitory concentration: 110 nM
The estimate for compound 4 lay 27-fold (1.44 log units) above the measured number, outside the stated range (below it).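

Methoxy in place of hydrogen on an aromatic carbon does not carry over as a fixed step in this assay, and its two measured cases run in opposite directions: the same change on two cores in this assay, a 21-fold higher number (1.33 log units; beyond the scatter) from compound 1 to compound 2 and a 4.5-fold lower number (0.66 log units; beyond the scatter) from compound 3 to compound 4, 97-fold (1.99 log units) apart, beyond the scatter of two such steps

On the bromoacrylamide core the change, read as 3-methoxyphenyl to 3,4-dimethoxyphenyl, gives a 4.5-fold lower number from compound 3 to compound 4 (0.66 log units; beyond the scatter), so neither the size nor the direction of a step read on one core can be applied to the other. This does not show what sets the two steps apart: the two cores differ in more than one place, the entering methoxy stands ortho to a methoxy group only in compound 4, and two examples cannot separate these differences.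

As far as these compounds go, it remains open whether the lower number from the added methoxy depends on the bromoacrylamide or on the methoxy group already present. From the compounds shown here alone, it also remains open whether a hydroxyl or an amine at the same place would follow the step seen for methoxy.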